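The source may hold more compounds than are shown below. What is called first, only, known or untested is meant among the compounds shown, and "the series" means these compounds.

Measured compounds:
compound 1 `COc1cc2c(Oc3ccc(NC(=O)c4cn(-c5ccccc5)nn4)cc3F)ccnc2cc1OCCCN1CCCC1`, 180 nM
compound 2 `COc1cc2c(Oc3ccc(NC(=O)c4cn(-c5ccc(Br)cc5)nn4)cc3F)ccnc2cc1OCCCN1CCCC1`, 190 nM

Compound 1 gives 180 nM in a functional assay on HT-29 cells (Homo sapiens) for cytotoxicity, read by MTT assay, with a stated time of 72 h (on this read-out lower numbers stand for stronger inhibition and higher numbers for weaker inhibition), the lowest of the two numbers, with compound 2 lying within the scatter of it: a 1.1-fold higher number from compound 1 to compound 2 (0.02 log units; within the scatter). Compound 3 `COc1cc2c(Oc3ccc(NC(=O)c4cn(-c5c(C)cccc5C)nn4)cc3F)ccnc2cc1OCCCN1CCCC1` differs from compound 1 in one place: 2,6-dimethylphenyl in place of phenyl on an aromatic nitrogen. Going by the values given here, the only measured step that bears on a change to this phenyl is the one from compound 1 to compound 2, a 1.1-fold higher number from compound 1 to compound 2 (0.02 log units; within the scatter), which shows that a substituent on that ring left the number within the scatter. Among the compounds with values here, no measured step covers two methyl groups placed as in 2,6-dimethylphenyl, so the expectation rests on that single step alone. Compound 3 is therefore expected to give 250 nM in this assay, with a range from 90 nM to 700 nM, meaning an expected step of a 1.4-fold higher number from compound 1 to compound 3 (0.14 log units; within the scatter), at most modestly beyond the scatter.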

Compound 3, half-maximal inhibitory concentration: 2240 nM
For compound 3 the middle estimate is 9.0-fold (0.95 log units) below the measured one, outside the stated range (above it).
By their numbers in this assay, from the lowest: compounds 1 and 2 (each within the scatter of the next); then compound 3.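

The phenyl on this aromatic nitrogen does not accept every change in this assay: replacing it with 2,6-dimethylphenyl gives a 12-fold higher number from compound 1 to compound 3 (1.09 log units; beyond the scatter), and replacing 4-bromophenyl with the same group gives a 12-fold higher number from compound 2 to compound 3 (1.07 log units; beyond the scatter). The earlier step, a 1.1-fold higher number from compound 1 to compound 2 (0.02 log units; within the scatter), had shown only that a bromo group could be added to this ring with no change beyond the scatter, so this is the first sign that the number depends on the group at this position. No available evidence accounts for the large difference between these changes.

The compounds shown leave open whether a single methyl group on the phenyl would give a similar step, since both methyl groups enter together in compound 3. They also leave open how this number would respond to an amine or a carboxylic acid on the ring.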